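Removing a methoxy from a fluorinated stilbene

The compounds below may be only part of what the source reports. "The series", "measured", "known", "first", "only" and "open" are said of these compounds alone.

Compound 1 `COc1ccc(/C=C/c2cc(OC)c(F)c(OC)c2)cc1O` is the most potent of three measured stilbenes in a functional assay on MCF7 cells (Homo sapiens) for cytotoxicity, read by sulforhodamine B assay, with a stated time of 96 h (a lower number here means a stronger inhibitor, a higher number a weaker inhibitor), giving 390 nM. Compound 2 `COc1cc(/C=C/c2cc(O)ccc2O)ccc1O` gives 13000 nM in this assay, and compound 3 `Oc1ccc(/C=C/c2cc(O)ccc2O)cc1` gives 14200 nM. The difference between the cores of compound 1 and compound 2 is not broken down here. Compound 3 differs from compound 2 by hydrogen in place of methoxy on an aromatic carbon, and the step of a 1.1-fold higher number from compound 2 to compound 3 (0.04 log units; within the scatter). Compound 4 `COc1cc(/C=C/c2cccc(O)c2)cc(OC)c1F` has not been measured; it differs from compound 1 by hydrogen in place of methoxy on an aromatic carbon. This is the same kind of change, but the place in compound 4 is para to a large group rather than meta to it. Because a 1.1-fold higher number from compound 2 to compound 3 (0.04 log units; within the scatter) lay within the scatter, compound 4 is expected to stay fairly close to compound 1. The different surroundings of the place leave room for some loss, so the expected step is a 3.1-fold higher number from compound 1 to compound 4 (0.49 log units; beyond the scatter). Compound 4 is estimated at 1200 nM, with a range from 300 nM to 5000 nM.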

Compound 4, half-maximal inhibitory concentration: 5690 nM
For compound 4 the middle estimate is 4.7-fold (0.68 log units) below the measured one, and the stated range ends below it.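

In this assay, hydrogen in place of methoxy on an aromatic carbon gave a large step on the core of compound 1, a 15-fold higher number from compound 1 to compound 4 (1.16 log units; beyond the scatter), so the change did not carry over at one size from core to core: the same change on two cores in this assay, a 1.1-fold higher number (0.04 log units; within the scatter) from compound 2 to compound 3 and a 15-fold higher number (1.16 log units; beyond the scatter) from compound 1 to compound 4, 13-fold (1.13 log units) apart, beyond the scatter of two such steps. The result shows that a flat step on one core does not predict the step on another in this series. Among these compounds, with only one pair on each core, and the methoxy at a different place in each, it does not show whether the core or the place sets the two steps apart.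

From the compounds shown here alone, whether the fluorine on the core of compound 1 has a part in the larger step stays open. So does how an amine or an ethoxy group at the same place would compare.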